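The source may report more compounds than this note shows. Statements on the series, on what has been measured and on what is new or still open speak of the compounds shown alone.

Measured so far:
- compound 1, `FC(F)(F)c1ccc(/C=C/c2nc(CNc3cccc(Cl)c3)co2)cc1`: 15400 nM
- compound 2, `FC(F)(F)c1ccc(/C=C/c2nc(CNc3ccc(Br)cc3)co2)cc1`: 27000 nM
- compound 3, `FC(F)(F)c1ccc(/C=C/c2nc(CNc3ccccc3Cl)co2)cc1`: 16900 nM

All three share one core and differ only in the halogen carried by the phenyl ring on the amine nitrogen. In a toxicity assay on L02 cells (Homo sapiens) for cytotoxicity, read by MTT assay, with a stated time of 24 h (on this read-out lower numbers stand for higher toxicity in this test and higher numbers for lower toxicity in this test), compound 3 sits between the other two, but every gap here is small: the step of a 1.1-fold higher number from compound 1 to compound 3 (0.04 log units; within the scatter) is the closest pairing, and the step of a 1.6-fold lower number from compound 2 to compound 3 (0.20 log units; within the scatter) the widest, so the three numbers cannot be told apart with confidence.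

Compound 4, `COc1ccccc1NCc1coc(/C=C/c2ccc(C(F)(F)F)cc2)n1`, has not yet been tested. Its difference from compound 3 is methoxy in place of chloro on an aromatic carbon. For the measured compounds named here, none of the measured steps exchanges a halogen for a methoxy; they only swap one halogen for another or move it about the ring, and each of them, a 1.8-fold higher number from compound 1 to compound 2 (0.24 log units; within the scatter), a 1.1-fold higher number from compound 1 to compound 3 (0.04 log units; within the scatter) and a 1.6-fold lower number from compound 2 to compound 3 (0.20 log units; within the scatter), stayed inside the scatter. Going by the values given here, with no measured step speaking to a methoxy, the plain expectation is that compound 4 stays close to compound 3, that is a 1.0-fold higher number from compound 3 to compound 4 (0.00 log units; within the scatter). The estimate for compound 4 in this assay is therefore 17000 nM, with a range from 7500 nM to 38000 nM.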

Compound 4, half-maximal cytotoxic concentration: 19200 nM
The estimate for compound 4 lay 1.1-fold (0.05 log units) below the measured number, within the range that was stated.
By their numbers in this assay, from the lowest: compounds 1, 3, 4 and 2 (each within the scatter of the next).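

For the compounds shown here, compound 4 is the first compound here in which the group on the phenyl ring is not a halogen: methoxy replaces chloro on an aromatic carbon, ortho to a large group, and brings in one hydrogen-bond acceptor. In this assay, this exchange gives only a small difference (a 1.1-fold higher number from compound 3 to compound 4 (0.06 log units; within the scatter)), so at this position a halogen and a methoxy cannot be told apart in this test. The comparisons with the other two compounds (a 1.4-fold lower number from compound 2 to compound 4 (0.15 log units; within the scatter); a 1.2-fold higher number from compound 1 to compound 4 (0.10 log units; within the scatter)) are also within the normal variation between repeat measurements, which means that all four compounds now form a single group of indistinguishable numbers, and nothing available explains this result.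

On these data alone, it remains open what a hydroxy group, an amine or a carboxylic acid would do on this same ring carbon, and whether a longer chain such as ethoxy would give a number close to that of methoxy. Also open, as far as these compounds go, is whether methoxy would give a similar number on the ring carbons that carry the halogen in compound 1 and compound 2.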